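Swapping a chloroaryl amide for an isobutyl amide

The compounds below may be only part of what the source reports. "The series", "measured", "known", "first", "only" and "open" are said of these compounds alone.

Of the compounds shown here, three sharing one core have been tested in an ADME assay on Vero cells (Chlorocebus sabaeus) for cytotoxicity, read by MTT assay, with a stated time of 72 h; a higher number here means that more compound is tolerated, a lower number that less compound is tolerated. Compound 1 `O=C(c1ccc(Cl)cc1)N1CCN(c2nc(=O)c3cc(C(F)(F)F)cc([N+](=O)[O-])c3s2)CC1` gives > 125000 nM, which is a limit of the assay rather than a number. Compound 2 `CCCCC(=O)N1CCN(c2nc(=O)c3cc(C(F)(F)F)cc([N+](=O)[O-])c3s2)CC1` gives > 125000 nM, again a limit. Compound 3 `O=C(c1cccc(F)c1)N1CCN(c2nc(=O)c3cc(C(F)(F)F)cc([N+](=O)[O-])c3s2)CC1` gives > 125000 nM, once more a limit. Because all three values sit at the limit of > 125000 nM in this assay, at which 3 of the 3 values shown sit, the measured steps cannot be sized: a step that the two limits leave unreadable from compound 1 to compound 2, a step that the two limits leave unreadable from compound 1 to compound 3 and a step that the two limits leave unreadable from compound 2 to compound 3 are all unreadable.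

Compound 4 `CC(C)CC(=O)N1CCN(c2nc(=O)c3cc(C(F)(F)F)cc([N+](=O)[O-])c3s2)CC1` has not yet been tested. Its change from compound 1 is isobutyl in place of 4-chlorophenyl on a carbonyl carbon. The nearest comparison is compound 2, whose butyl group on the same carbonyl carbon also left the value at the limit. Within the data shown here, no step shows any movement below the limit.

The expected step from compound 1 to compound 4 in this assay is therefore a step that the limit leaves unreadable from compound 1 to compound 4. Compound 4 is expected to give about 200000 nM, within 100000 nM to 500000 nM, and most probably the assay will again report only a limit.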

Compound 4, half-maximal cytotoxic concentration: > 125000 nM
Compound 4 gave a limit, no number; the forecaster's own chance of this, stated with the estimate: 85%; the middle value does not contradict the limit.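

Compound 4 also gives only a limit in this assay, so its steps from compound 1, compound 2 and compound 3 cannot be read: the limit of > 125000 nM in this assay, at which 4 of the 4 values shown sit.

Still open, from the compounds shown here alone, is what concentration of any of these four compounds harms the cells, and whether the group on the carbonyl carbon changes that concentration at all.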